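The compounds below may be only part of what the source reports. "The series", "measured", "known", "first", "only" and "open" are said of these compounds alone.

Of the compounds shown here, three built on one shared core have been tested in an ADME assay on Vero cells (Chlorocebus sabaeus) for cytotoxicity, read by MTT assay, with a stated time of 72 h; on this read-out higher numbers stand for lower toxicity in this test and lower numbers for higher toxicity in this test. Compound 1 `COc1c(N2CCN(CCC#N)C(C)C2)c(F)cc2c(=O)c(C(=O)O)cn(C3CC3)c12` gives 500 ug/mL in this assay. Compound 3 `COc1c(N2CCN(CC/C(C)=N/O)C(C)C2)c(F)cc2c(=O)c(C(=O)O)cn(C3CC3)c12` gives 44.2 ug/mL in this assay. Compound 2 `COC(=O)CCN1CCN(c2c(F)cc3c(=O)c(C(=O)O)cn(C4CC4)c3c2OC)CC1C` gives only > 1000 ug/mL in this assay, which is a limit of the test and not a number, as the limit of > 1000 ug/mL in this assay, at which 1 of the 3 values shown sits, records.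

The step to follow runs from compound 2 to compound 4 `CCO/N=C(\C)CCN1CCN(c2c(F)cc3c(=O)c(C(=O)O)cn(C4CC4)c3c2OC)CC1C`. The change is a group of 6 heavy atoms (4 carbon, 1 nitrogen, 1 oxygen; no ring) in place of a group of 4 heavy atoms (2 carbon, 2 oxygen; no ring), on a saturated chain carbon, two bonds along the chain from an amine nitrogen in a ring. Going by the values given here, two measured steps bear on it. The closest is an at least 22-fold lower number from compound 2 to compound 3 (1.35 log units; beyond the scatter), where a group holding nitrogen and oxygen on a chain entered at the same place. The step of an 11-fold lower number from compound 1 to compound 3 (1.05 log units; beyond the scatter) points the same way. By contrast, an at least 2.0-fold higher number from compound 1 to compound 2 (0.30 log units; that floor lies within the scatter) is only a floor that lies within the scatter, so it gives no direction of its own. The group of 6 heavy atoms (4 carbon, 1 nitrogen, 1 oxygen; no ring) entering in compound 4 resembles the group of 4 heavy atoms (2 carbon, 1 nitrogen, 1 oxygen; no ring) of compound 3 more than the methoxycarbonyl it replaces, so a large step toward a lower number is expected in this assay.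

Compound 4 is therefore estimated to give about 60 ug/mL, with a likely range from 15 ug/mL to 250 ug/mL. The expected step is an at least 16-fold lower number from compound 2 to compound 4 (1.22 log units; beyond the scatter).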

Compound 4, half-maximal cytotoxic concentration: 88.4 ug/mL
For compound 4 the middle estimate is 1.5-fold (0.17 log units) below the measured one, within the range that was stated.
By their numbers in this assay, from the lowest: compounds 3 and 4 (each within the scatter of the next); then compound 1. At a limit, above all of these: compound 2.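

In this assay, ethyl in place of hydrogen on an oxygen at the end of the chain leaves no readable change, as a 2.0-fold higher number from compound 3 to compound 4 (0.30 log units; within the scatter) shows, so the free hydrogen on that oxygen of compound 3 is not needed for its low number. The larger group of compound 4 still stands apart from the other two chain ends, with a 5.7-fold lower number from compound 1 to compound 4 (0.75 log units; beyond the scatter) and an at least 11-fold lower number from compound 2 to compound 4 (1.05 log units; beyond the scatter), so the drop in the number seen with compound 3 is not confined to one group and holds for both compounds whose chain ends carry nitrogen and oxygen. The step from compound 2 is only a floor, since compound 2 is held at a limit of the test and not at a number: the limit of > 1000 ug/mL in this assay, at which 1 of the 4 values shown sits.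

From the compounds shown here alone, it remains open whether a longer chain on that oxygen, a benzyl group there, or an amine at the end of the chain would keep the number where compound 3 and compound 4 sit. A carboxylic acid in place of the methoxycarbonyl of compound 2 is also an open case, and it could show whether the high limit belongs to the ester alone.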